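Changing the side chain of compound 3

This account rests on a few compounds, and the source may have more. Where it says the series, first, only, none or still open, it means among the compounds named here.

compound 1 `CCN(CC)CCNC(=O)c1ccc(C(CC)(CC)c2ccc(OCC(=O)C(C)(C)C)c(C)c2)n1CC` gives 30 nM
compound 2 `CCn1c(C(=O)NCCCN(C)C)ccc1C(CC)(CC)c1ccc(OCC(=O)C(C)(C)C)c(C)c1` gives 1600 nM
compound 3 `CCn1c(C(=O)NCCCN(C)C)ccc1C(CC)(CC)c1ccc(OCC(O)C(C)(C)C)c(C)c1` gives 3100 nM

These values come from a functional assay on PC-3 cells (Homo sapiens), read by MTT assay, with a stated time of 48 h (a lower number here means a stronger inhibitor, a higher number a weaker inhibitor), and there compound 3 has a far higher number than compound 1 but stays level with compound 2 (a 1.9-fold higher number from compound 2 to compound 3 (0.29 log units; within the scatter)). Compound 4 `CCn1c(C(=O)N(C)CCC#N)ccc1C(CC)(CC)c1ccc(OCC(O)C(C)(C)C)c(C)c1` keeps the rest of compound 3 and carries (2-cyanoethyl)(methyl)amino in place of (3-(dimethylamino)propyl)amino on a carbonyl carbon. Among the compounds with values here, the one measured change in this side chain was large (a 53-fold higher number from compound 1 to compound 2 (1.73 log units; beyond the scatter)) and shows that this part can move the number a long way. That change was a different one, so it gives no direct size. The other measured step lies elsewhere in the molecule and bears little on this change. A moderate rise is expected (a 1.9-fold higher number from compound 3 to compound 4 (0.29 log units; within the scatter)) with wide uncertainty. Compound 4 is estimated at 6000 nM in this assay with 1500 nM to 25000 nM as its expected range.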

Compound 4, half-maximal inhibitory concentration: 1700 nM
Compound 4: the middle estimate sits 3.5-fold (0.55 log units) above what was measured, and the stated range covers the measured number.
By their numbers in this assay, from the lowest: compound 1; then compounds 2, 4 and 3 (each within the scatter of the next).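

In this assay, putting (2-cyanoethyl)(methyl)amino in place of (3-(dimethylamino)propyl)amino on a carbonyl carbon leaves the number level (a 1.8-fold lower number from compound 3 to compound 4 (0.26 log units; within the scatter)). The side chain that gave a large step earlier (a 53-fold higher number from compound 1 to compound 2 (1.73 log units; beyond the scatter)) can therefore lose its amide hydrogen and its dimethylamino end in compound 4 with no change beyond the scatter. Nothing measured here explains this result. From the compounds shown here alone, whether a piperidine ring or a carboxylic acid on that carbonyl carbon would keep the number at this level remains open. So does whether the diethylamino chain of compound 1 would keep its low number alongside the hydroxyl group of compound 3.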